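Dropping the Trifluoromethyl Group from Compound 1

The source may hold more compounds than are shown below. What is called first, only, known or untested is meant among the compounds shown, and "the series" means these compounds.

Measured in an ADME assay on HEK293 cells (Homo sapiens) for cytotoxicity, read by MTT assay, with a stated time of 24 h; on this read-out higher numbers stand for weaker inhibition and lower numbers for stronger inhibition:
Compound 1 `CN(C)CCCNc1nc2cc([N+](=O)[O-])ccc2nc1NCc1ccc(C(F)(F)F)cc1`: 5.66 ug/mL.
Compound 2 `O=[N+]([O-])c1ccc2nc(NCc3ccc(C(F)(F)F)cc3)c(N3CCCCC3)nc2c1`: > 200 ug/mL, a limit of the assay.
Compound 3 `O=[N+]([O-])c1ccc2nc(NCc3ccc(C(F)(F)F)cc3)c(N3CCNCC3)nc2c1`: 9.61 ug/mL.

Compound 1 stands among the two true numbers, and these lie close together: a 1.7-fold higher number from compound 1 to compound 3 (0.23 log units; within the scatter). The only other result is the limit: the limit of > 200 ug/mL in this assay, at which 1 of the 3 values shown sits.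

Compound 4 `CN(C)CCCNc1nc2cc([N+](=O)[O-])ccc2nc1NCc1ccccc1` carries hydrogen in place of trifluoromethyl on an aromatic carbon, para to a large group: hydrogen in place of trifluoromethyl on an aromatic carbon. Among the measured compounds shown here, no measured step touches this place. The large steps of an at least 35-fold higher number from compound 1 to compound 2 (1.54 log units; beyond the scatter) and an at least 20-fold lower number from compound 2 to compound 3 (1.31 log units; beyond the scatter) concern a different substituent, so they only argue for a wide range. No shift beyond the scatter is therefore expected, and the estimated step is a 1.2-fold higher number from compound 1 to compound 4 (0.09 log units; within the scatter). For compound 4 the expected value is 7 ug/mL, with an estimated range of 2.5 ug/mL to 25 ug/mL.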

Compound 4, half-maximal inhibitory concentration: 2.74 ug/mL
For compound 4 the middle estimate is 2.6-fold (0.41 log units) above the measured one; measured number inside the range.
By their numbers in this assay, from the lowest: compound 4; then compounds 1 and 3 (each within the scatter of the next). At a limit, above all of these: compound 2.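

The change from 4-(trifluoromethyl)phenyl to phenyl is the only step shown at this position, and in this assay it gives a 2.1-fold lower number from compound 1 to compound 4 (0.32 log units; beyond the scatter). This position therefore also moves the read-out beyond the scatter, though only modestly compared with the large steps at the other substituent, and the compound stays on the low side without trifluoromethyl. Nothing in the data shown accounts for this step. From the compounds shown here alone, it remains open how a chlorine atom, a methoxy group or a carboxylic acid at this place would read. Going by these compounds, it is also open whether the same change would shift compound 3 or compound 2 in the same direction.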